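Quinolinyl Replaces Tetrahydronaphthalenyl Before Compound 3 Is Measured

The compounds below may be only part of what the source reports. "The series", "measured", "known", "first", "only" and "open" are said of these compounds alone.

Of the compounds shown here, two with a shared core have so far been tested in an assay for inhibition of Polyunsaturated fatty acid 5-lipoxygenase (Homo sapiens), read by HPLC, with a stated time of 10 min; on this read-out lower numbers stand for stronger inhibition and higher numbers for weaker inhibition. Compound 1, `CCCCC(Sc1ccc(OCCCOc2ccc(-c3ccccc3)cc2)cc1)C(=O)O`, gives 3500 nM. Compound 2, `CCCCC(Sc1ccc(OCCCOc2cccc3c2CCCC3)cc1)C(=O)OCC`, gives only > 10000 nM, which is a limit of the assay rather than a number. This is the limit of > 10000 nM in this assay, at which 1 of the 2 values shown sits. Compound 2 therefore stands at the weak end of what has been measured, with no exact figure of its own. Compound 3, `CCCCC(Sc1ccc(OCCCOc2ccc3ncccc3c2)cc1)C(=O)OCC`, differs from compound 2 in one place: quinolin-6-yl in place of 1,2,3,4-tetrahydronaphthalen-5-yl on an oxygen on a saturated carbon. For the measured compounds named here, no measured pair shows this change, so its effect is open; the expected step is an at least 1.2-fold lower number from compound 2 to compound 3 (0.09 log units; that floor lies within the scatter), a modest gain that may still not reach beyond the scatter. Compound 3 is expected to give 8000 nM, with a range from 2500 nM to 30000 nM.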

Compound 3, half-maximal inhibitory concentration: > 10000 nM
Compound 3 ended at the assay's limit; the forecaster's own chance of this, stated with the estimate: 55%; middle value at least 1.2-fold (0.09 log units) away from the limit.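

In this assay compound 2 and compound 3 both stand at a limit rather than a number, so no step can be read between them: the limit of > 10000 nM in this assay, at which 2 of the 3 values shown sit.

On these data alone, whether quinolin-6-yl in place of 1,2,3,4-tetrahydronaphthalen-5-yl changes inhibition at all, and in which direction, stays open.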